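An Unmeasured Swap on a Carbonyl Carbon

A few compounds are considered here, and "the series" means these few. Any claim that something is new, unique, unknown or untested is made for them only; others in the source may bear on it.

Among the measured compounds shown here, in a functional assay on Z-138 cells (Homo sapiens) for inhibition, read by luminescence and CellTiter-Glo, with a stated time of 72 h (on this read-out lower numbers stand for stronger inhibition and higher numbers for weaker inhibition), compound 1 `C/C=C/C(=O)N1CCCC(n2nc(-c3ccc(Oc4ccccc4)cc3)cc2C(=O)OCC)C1` gives 19100 nM and is the only compound here with a true number. Compound 2 `C=CC(=O)N1CCCC(n2nc(-c3ccc(Oc4ccccc4)cc3)cc2C(=O)O)C1` reads > 60000 nM in this assay as a limit of the assay and not a number. Its standing is therefore the limit of > 60000 nM in this assay, at which 1 of the 2 values shown sits, and nothing finer can be said of it.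

Compound 3 `C/C=C/C(=O)N1CCCC(n2nc(-c3ccc(Oc4ccccc4)cc3)cc2C(=O)O)C1` differs from compound 2 by a single change prop-1-en-1-yl in place of vinyl on a carbonyl carbon with prop-1-en-1-yl in place of vinyl on a carbonyl carbon. For the measured compounds named here, no measured step shows what this change does, so no shift beyond the scatter is expected in this assay and another reading at the limit remains likely. That expectation means an estimated step of a number no higher from compound 2 to compound 3 (the limit leaves the size open) no larger than the scatter. Compound 3 is estimated at 60000 nM within an expected range of 30000 nM to 120000 nM on this read-out.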

Compound 3, half-maximal inhibitory concentration: > 60000 nM
Compound 3 was reported as a limit; the forecaster's own chance of this, stated with the estimate: 65%; the middle value sits exactly at the limit.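

In this assay, the new compound gives the first readable effect of a change on the oxygen next to a carbonyl group: with hydrogen in place of ethyl, the series shows an at least 3.1-fold higher number from compound 1 to compound 3 (0.49 log units; beyond the scatter). The step from compound 2 to compound 3 cannot be read, so prop-1-en-1-yl in place of vinyl on a carbonyl carbon has no measurable effect to report here. Compound 2 and compound 3, which both carry that hydrogen, stand together at a limit of the assay and not at a number: the limit of > 60000 nM in this assay, at which 2 of the 3 values shown sit.

As far as these compounds go, what the swap of vinyl for prop-1-en-1-yl does while the ethyl group stays in place remains open. So does how far the number would move with a longer chain, such as butyl, in place of ethyl on that oxygen.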